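A few compounds are considered here, and "the series" means these few. Any claim that something is new, unique, unknown or untested is made for them only; others in the source may bear on it.

Measured compounds in an assay on SK-N-MC cells for inhibition of Neuropeptide Y receptor type 1 (Homo sapiens); on this read-out higher numbers stand for weaker inhibition and lower numbers for stronger inhibition:
- compound 1 `COC(=O)C1=C(C)N=C(C)/C(=C(/O)OC)C1c1cccc(NC(=O)NCCNC2CCN(c3ccccc3C)CC2)c1`: 4 nM
- compound 2 `COC(=O)C1=C(C)N=C(C)/C(=C(/O)OC)C1c1cccc(NC(=O)NCCNC2CCN(c3ccccc3OC)CC2)c1`: 2 nM

Among the measured compounds shown here, compound 2 carries the lowest of the two numbers so far, but its step from compound 1 is small: a 2.0-fold lower number from compound 1 to compound 2 (0.30 log units; within the scatter). On this read-out the two compounds are not separable.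

Compound 3 `COC(=O)C1=C(C)N=C(C)/C(=C(/O)OC)C1c1cccc(NC(=O)NCCNC2CCN(c3ccccc3O)CC2)c1` is not yet measured. Its change from compound 2 is hydrogen in place of methyl on an oxygen on an aromatic ring. For the measured compounds named here, the only measured step concerns the same position on the aromatic ring, where methoxy replaced methyl, and it stayed within the scatter. Going by the values given here, no measured step removes the methyl from the oxygen to leave hydroxy, so nothing directly bears on this change. Given that the one step at this position, from compound 1 to compound 2, was small, the step of a 2.0-fold higher number from compound 2 to compound 3 (0.30 log units; within the scatter) is expected to be modest and may not exceed the scatter. Compound 3 is therefore estimated at 4 nM in this assay, with a range from 1 nM to 15 nM.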

Compound 3, half-maximal inhibitory concentration: 6 nM
Estimate against measurement, compound 3: 1.5-fold (0.18 log units) below; measured number inside the range.
By their numbers in this assay, from the lowest: compounds 2, 1 and 3 (each within the scatter of the next, the first and the last beyond it).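

In this assay, among the compounds shown here, removing the methyl from the oxygen, methoxy to hydroxy, gives a 3.0-fold higher number from compound 2 to compound 3 (0.48 log units; beyond the scatter) and is the first step at this place on the aromatic ring to lie beyond the scatter, though it remains modest. Hydroxy and methyl on the aromatic carbon remain inseparable, with a 1.5-fold higher number from compound 1 to compound 3 (0.18 log units; within the scatter) as the step between them, so the three groups span only a narrow range and only compound 2 and compound 3 can be told apart. The data offer no evidence on what lies behind the methoxy to hydroxy step.

Open, going by these compounds, is whether a larger group on this oxygen, such as ethoxy or benzyloxy in place of methoxy, keeps the number as low as methoxy does. Also open, on these data alone, is how an amine or a carboxylic acid at this place on the aromatic ring would read.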